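Swapping one ring group on the core of compound 1

A few compounds are considered here, and "the series" means these few. Any claim that something is new, unique, unknown or untested is made for them only; others in the source may bear on it.

Compound 1 `CC1(C)C[C@H](c2cccc[n+]2[O-])c2cc(C#N)ccc2O1`: 210 nM
Compound 2 `CC1(C)Oc2ccc(C#N)cc2[C@@H](c2cccc[n+]2[O-])[C@@H]1O`: 100 nM

In a functional assay with Rattus norvegicus as the target (a lower number here means a stronger inhibitor, a higher number a weaker inhibitor), compound 1 gives 210 nM, the higher of the two numbers. Compound 3 `CC1(C)C[C@H](N2CCCC2=O)c2cc(C#N)ccc2O1` keeps the core of compound 1 and carries a group of 6 heavy atoms (4 carbon, 1 nitrogen, 1 oxygen; one five-membered non-aromatic ring with 1 hetero atom) in place of a group of 7 heavy atoms (5 carbon, 1 nitrogen, 1 oxygen; one six-membered aromatic ring with 1 hetero atom), on a saturated ring carbon. Going by the values given here, the only measured step is a 2.1-fold lower number from compound 1 to compound 2 (0.32 log units; beyond the scatter), a modest one that comes from hydroxy in place of hydrogen on a saturated ring carbon. Among the compounds with values here, it does not test this swap, and no measured compound carries the 2-oxopyrrolidin-1-yl group, so the direction stays open. The expected change is small, a 1.4-fold higher number from compound 1 to compound 3 (0.15 log units; within the scatter), within the scatter. For compound 3 the estimate is 300 nM, with an expected range of 60 nM to 1500 nM.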

Compound 3, half-maximal inhibitory concentration: 1150 nM
The estimate for compound 3 lay 3.8-fold (0.58 log units) below the measured number; measured number inside the range.
By their numbers in this assay, from the lowest: compound 2; then compound 1; then compound 3.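

In this assay the exchange of the six-membered aromatic ring group for 2-oxopyrrolidin-1-yl on the saturated ring carbon gives a 5.5-fold higher number from compound 1 to compound 3 (0.74 log units; beyond the scatter) and so shows that the number responds to which ring group sits at this position, something the hydroxy step could not show. Compound 3 thus gives up the number held by compound 1 even though the two groups match in hydrogen-bond donors and acceptors as counted. Nothing available explains this difference.

From the compounds shown here alone, how a phenyl ring or an open-chain amine at this carbon would compare stays open. So does whether a hydroxy group, added to compound 3, would lower its number.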